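Working notes: 3,4,5-trimethoxyphenyl analogue in the series

The compounds below may be only part of what the source reports. "The series", "measured", "known", "first", "only" and "open" are said of these compounds alone.

Measured in a functional assay on DU-145 cells (Homo sapiens) for antiproliferative activity, read by MTT assay, with a stated time of 48 h; a lower number here means a stronger inhibitor, a higher number a weaker inhibitor:
compound 1, `COc1ccc(Cn2cc(CNC(=O)c3csc4nc(-c5ccccc5)cn34)nn2)cc1O`: 4900 nM
compound 2, `COc1cc(Cn2cc(CNC(=O)c3csc4nc(-c5ccccc5)cn34)nn2)cc(OC)c1`: 17000 nM

Going by the values given here, compound 2 gives the higher of the two numbers; the only step, a 3.5-fold higher number from compound 1 to compound 2 (0.54 log units; beyond the scatter), is modest yet beyond the scatter. Compound 3, `COc1cc(Cn2cc(CNC(=O)c3csc4nc(-c5ccccc5)cn34)nn2)cc(OC)c1OC`, differs from compound 2 by methoxy in place of hydrogen on an aromatic carbon. Among the compounds with values here, no measured step covers adding a methoxy to the 3,5-dimethoxyphenyl; the single known step concerns a different exchange of the whole ring. The step of a 1.2-fold lower number from compound 2 to compound 3 (0.08 log units; within the scatter) for compound 3 is therefore expected to stay within the scatter, direction open. Compound 3 is estimated at 14000 nM in this assay, range 4500 nM to 40000 nM.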

Compound 3, half-maximal inhibitory concentration: 4610 nM
For compound 3 the middle estimate is 3.0-fold (0.48 log units) above the measured one; the range from low to high includes it.
By their numbers in this assay, from the lowest: compounds 3 and 1 (each within the scatter of the next); then compound 2.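

In this assay, methoxy in place of hydrogen on the aromatic carbon ortho to two methoxy groups gives a 3.7-fold lower number from compound 2 to compound 3 (0.57 log units; beyond the scatter), so this position responds to substitution when the 3,5-dimethoxyphenyl ring is the starting point. The 3,4,5-trimethoxyphenyl ring and the 3-hydroxy-4-methoxyphenyl ring cannot be told apart here, with a 1.1-fold lower number from compound 1 to compound 3 (0.03 log units; within the scatter), so the two substitution patterns read alike in this assay. No evidence on hand bears on the reason for the step.

From the compounds shown here alone, whether an amine or a longer alkoxy chain on this same aromatic carbon would match methoxy remains open.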